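The source may report more compounds than this note shows. Statements on the series, on what has been measured and on what is new or still open speak of the compounds shown alone.

Working notes on the series, read in a functional assay on LNCaP cells (Homo sapiens) for cytotoxicity; a lower number here means a stronger inhibitor, a higher number a weaker inhibitor. Compound 1 (`CNC(=O)Nc1ccc(-c2nc(N3CC4CCC(C3)O4)c3cnn(C(C)C)c3n2)cc1`) gives 5 nM. Compound 2 (`CNC(=O)Nc1ccc(-c2nc(N3CC4CCC(C3)O4)c3cnn(CCN(C)C)c3n2)cc1`) gives 400 nM. These two structures differ in one place only, and the step is an 80-fold higher number from compound 1 to compound 2 (1.90 log units; beyond the scatter). Compound 3 (`O=C(Nc1ccccc1)Nc1ccc(-c2nc(N3CC4CCC(C3)O4)c3cnn(C4CCC5(CC4)OCCO5)c3n2)cc1`) gives 4 nM, the lowest of the three numbers, but it lies within the scatter of compound 1 at 5 nM. It stands well apart from compound 2 at 400 nM.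

Compound 4 (`O=C(Nc1ccc(-c2nc(N3CC4CCC(C3)O4)c3cnn(C4CCC5(CC4)OCCO5)c3n2)cc1)Nc1cccnc1`) keeps everything in compound 3 except one group, with pyridin-3-yl in place of phenyl on an amide-type nitrogen.

Among the compounds with values here, no measured step touches this place. The only one, an 80-fold higher number from compound 1 to compound 2 (1.90 log units; beyond the scatter), is large but concerns a different group on an aromatic nitrogen, so it gives no guide to size or direction here. The anchor is therefore compound 3 at 4 nM. As far as these compounds go, no step beyond the scatter is expected in this assay, and neither direction is favoured, though the range is kept wide since this place is untested. The expected step is no change at the digits printed from compound 3 to compound 4 (within the scatter). For compound 4 the estimated value is 4 nM, with an expected range from 1.5 nM to 15 nM.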

Compound 4, half-maximal inhibitory concentration: 1 nM
Compound 4: middle estimate off by 4.0-fold (0.60 log units), on the high side; measured number outside the range, below it.
By their numbers in this assay, from the lowest: compound 4; then compounds 3 and 1 (each within the scatter of the next); then compound 2.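

In this assay, within the data shown here, pyridin-3-yl in place of phenyl on the amide-type nitrogen gives a 4.0-fold lower number from compound 3 to compound 4 (0.60 log units; beyond the scatter), the first reading at this place, and it shows that the place responds to a change within the aromatic ring, with 1 nitrogen and 1 hydrogen-bond acceptor entering at an unchanged count of 6 heavy atoms. Among these compounds, the only earlier step, an 80-fold higher number from compound 1 to compound 2 (1.90 log units; beyond the scatter), concerns a different group on an aromatic nitrogen and runs towards a higher number, whereas this one shows that the series can still move to a lower number from compound 3 at 4 nM, with compound 4 at 1 nM. No measurement available here bears on why this exchange lowers the number.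

The compounds shown leave open whether the step depends on where the ring nitrogen sits, which pyridin-2-yl or pyridin-4-yl on the same amide-type nitrogen would test, and whether an amine or a carboxylic acid on the ring would be tolerated. They also leave open whether pyridin-3-yl gives a similar step when isopropyl or 2-(dimethylamino)ethyl sits on the aromatic nitrogen.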